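Trimethylphenyl to dimethylphenyl on the shared core

This account rests on a few compounds, and the source may have more. Where it says the series, first, only, none or still open, it means among the compounds named here.

Of the compounds shown here, two have numbers so far. Compound 1 `CC[C@H](C1CC1)n1c(=O)c(C)nc2c(-c3ccc(Cl)cc3Cl)ccnc21` carries a dichlorophenyl group on the shared core; in a functional assay for antagonist activity at corticotropin-releasing factor receptor 1 (Rattus norvegicus) (on this read-out higher numbers stand for weaker inhibition and lower numbers for stronger inhibition), compound 1 gives 8.2 nM. Compound 2 `CCC(C1CC1)n1c(=O)c(C)nc2c(-c3cc(C)c(C)cc3C)ccnc21` carries a 2,4,5-trimethylphenyl group in the same position; in this assay compound 2 gives 5.2 nM. Compound 2 holds the lowest of the two numbers, but compound 1 stands within the scatter of it, so the two values cannot be told apart.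

Compound 3 `CCC(C1CC1)n1c(=O)c(C)nc2c(-c3ccc(C)cc3C)ccnc21` is not yet measured. Relative to compound 2 the change is hydrogen in place of methyl on an aromatic carbon, so the 2,4,5-trimethylphenyl group becomes a 2,4-dimethylphenyl group. Within the data shown here, no pair of measured compounds differs in one place, so the size of this step has no precedent here. Since compound 1 gives 8.2 nM and compound 2 gives 5.2 nM with two different aryl groups, the series appears tolerant at this position, and the expected step is a 1.5-fold higher number from compound 2 to compound 3 (0.19 log units; within the scatter), none beyond the scatter or a slight weakening. Compound 3 is estimated to give 8 nM in this assay, expected between 3 nM and 22 nM.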

Compound 3, half-maximal inhibitory concentration: 8.8 nM
Beside the measured number, compound 3's estimate is 1.1-fold (0.04 log units) below it; measured number inside the range.
By their numbers in this assay, from the lowest: compounds 2, 1 and 3 (each within the scatter of the next).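

Among these compounds, this is the first step that differs in one place, and it gives a size for the change. In this assay, hydrogen in place of methyl on this aromatic carbon, ortho to a methyl group and para to another, gives a 1.7-fold higher number from compound 2 to compound 3 (0.23 log units; within the scatter). The 2,4,5-trimethylphenyl and 2,4-dimethylphenyl groups therefore cannot be told apart on this read-out, so this one methyl group makes no difference that can be read beyond the scatter, and nothing at hand bears on the reason for this.

From the compounds shown here alone, the comparison at this carbon covers only methyl and hydrogen, so it remains open whether a methoxy group, an amine, a carboxylic acid or a longer chain such as propyl would also stay within the scatter. The compounds shown also leave open what removing either of the two remaining methyl groups from the 2,4-dimethylphenyl group would do, since neither has a single-place step of its own here.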